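The source may hold more compounds than are shown below. What is called first, only, known or untested is meant among the compounds shown, and "the series" means these compounds.

Compound 1 `CN(C(=O)NC(=O)c1ccc(F)c(F)c1)c1nc(C(F)(F)F)c(C(=O)N/N=C/c2cc(C(F)(F)F)cc(C(F)(F)F)c2)s1` gives 2.61 ug/mL in a functional assay on MCF7 cells (Homo sapiens) for inhibition, read by MTT assay, with a stated time of 72 h; a higher number here means a weaker inhibitor, a lower number a stronger inhibitor.
Compound 2 `Cc1nc(N(C)C(=O)NC(=O)c2c(F)cccc2F)sc1C(=O)N/N=C/c1cccc(C(F)(F)F)c1` gives 28.2 ug/mL in this assay.
Compound 3 `CN(C(=O)NC(=O)c1ccc(F)c(F)c1)c1nc(C(F)(F)F)c(C(=O)N/N=C/c2cccc(C(F)(F)F)c2)s1` gives 4.15 ug/mL in this assay.

Compound 4 `Cc1nc(N(C)C(=O)NC(=O)c2c(F)cccc2F)sc1C(=O)N/N=C/c1cc(C(F)(F)F)cc(C(F)(F)F)c1` has not yet been measured. It differs from compound 2 in one place: trifluoromethyl in place of hydrogen on an aromatic carbon. The same change separates compound 3 from compound 1: trifluoromethyl in place of hydrogen on an aromatic carbon, and in that measured pair it made a 1.6-fold lower number from compound 3 to compound 1 (0.20 log units; within the scatter). For the measured compounds named here, the cores of compound 2 and compound 3 differ from each other, but that difference is not broken down here; the numbers show only that compound 2 gives the highest value of the three, beyond the scatter from both others. Because the measured step of a 1.6-fold lower number from compound 3 to compound 1 (0.20 log units; within the scatter) was small, a step of similar size is expected here: a 1.6-fold lower number from compound 2 to compound 4 (0.19 log units; within the scatter). Compound 4 is therefore estimated at 18 ug/mL, most likely between 9 ug/mL and 36 ug/mL.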

Compound 4, half-maximal inhibitory concentration: 11.6 ug/mL
The estimate for compound 4 lay 1.6-fold (0.19 log units) above the measured number, and the stated range covers the measured number.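

In this assay, trifluoromethyl in place of hydrogen on an aromatic carbon gives a 2.4-fold lower number from compound 2 to compound 4 (0.39 log units; beyond the scatter). Set beside the same change on the other core, the two steps cannot be told apart, so the change carries over between these two cores: the same change on two cores in this assay, a 1.6-fold lower number (0.20 log units; within the scatter) from compound 3 to compound 1 and a 2.4-fold lower number (0.39 log units; beyond the scatter) from compound 2 to compound 4, 1.5-fold (0.18 log units) apart, within the scatter of two such steps With only two pairs, this does not show that the step would hold on any further core, and it gives no reason for the step's size.

The compounds shown carry only hydrogen or trifluoromethyl at this place, so it remains open how a chlorine atom, a methoxy group or an amine would compare there. As far as these compounds go, the two cores also differ in more than one place, and what each of those differences contributes alone stays open.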